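Aryl swap on the ring nitrogen: compound 3 to compound 4

A few compounds are considered here, and "the series" means these few. Any claim that something is new, unique, unknown or untested is made for them only; others in the source may bear on it.

Working notes on a terpenoid ester series carrying a five-membered aromatic ring with three nitrogens, varied at the aryl on one ring nitrogen. Compound 1 `C/C(=C\CC/C(C)=C/CC[C@@H]1[C@@]2(C)CCC(=O)C(C)(C)[C@H]2CC[C@@]1(C)O)CC/C=C(\C)C(=O)OCc1cn(-c2ccccc2[N+](=O)[O-])nn1` bears a 2-nitrophenyl there, compound 2 `C/C(=C\CC/C(C)=C/CC[C@@H]1[C@@]2(C)CCC(=O)C(C)(C)[C@H]2CC[C@@]1(C)O)CC/C=C(\C)C(=O)OCc1cn(-c2ccccc2F)nn1` a 2-fluorophenyl, and compound 3 `C/C(=C\CC/C(C)=C/CC[C@@H]1[C@@]2(C)CCC(=O)C(C)(C)[C@H]2CC[C@@]1(C)O)CC/C=C(\C)C(=O)OCc1cn(-c2ccc(Cl)cc2)nn1` a 4-chlorophenyl. In an ADME assay on L132 cells (Homo sapiens) for cytotoxicity, read by MTT assay, with a stated time of 48 h (a higher number here means a weaker inhibitor, a lower number a stronger inhibitor), compound 1 reaches only a limit of the assay, > 150000 nM. In this assay compound 2 likewise reports only a limit, > 150000 nM. In this assay compound 3 also gives a limit, > 150000 nM. Hence a step that the two limits leave unreadable from compound 1 to compound 2, a step that the two limits leave unreadable from compound 1 to compound 3 and a step that the two limits leave unreadable from compound 2 to compound 3 are all unreadable in size; compound 3 stands with the other two at the limit of > 150000 nM in this assay, at which 3 of the 3 values shown sit, and nothing in the shown numbers sets it apart from them.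

Compound 4 `C/C(=C\CC/C(C)=C/CC[C@@H]1[C@@]2(C)CCC(=O)C(C)(C)[C@H]2CC[C@@]1(C)O)CC/C=C(\C)C(=O)OCc1cn(-c2cccc(C)c2)nn1` differs from compound 3 only in the aryl on the ring nitrogen: 3-methylphenyl in place of 4-chlorophenyl on an aromatic nitrogen. Among the compounds with values here, no measured step bears on this change with a readable size; all three end at the limit. Compound 4 is expected to show a step of a number no higher from compound 3 to compound 4 (the limit leaves the size open), most likely sitting again at the limit. Compound 4 is estimated at 150000 nM in this assay, within 75000 nM to 300000 nM.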

Compound 4, half-maximal inhibitory concentration: > 150000 nM
Compound 4 was reported as a limit; the forecaster's own chance of this, stated with the estimate: 85%; the middle value lies on the limit itself.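

In this assay compound 4 gives > 150000 nM as a limit of the assay. No new step can be read, as the steps joining compound 4 to compound 1, compound 2 and compound 3 all end at the same limit: the limit of > 150000 nM in this assay, at which 4 of the 4 values shown sit. As far as these compounds go, whether any aryl on the ring nitrogen gives a number rather than a limit in this assay remains open.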